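Ring size at the thiocarbonyl: piperidine to pyrrolidine

The compounds below may be only part of what the source reports. "The series", "measured", "known", "first", "only" and "open" are said of these compounds alone.

Measured compounds:
compound 1, `N/C(=N\NC(=S)N1CCCC1)c1ccc(F)cn1`: 72.7%
compound 2, `N/C(=N\NC(=S)N1CCCCC1)c1ccccn1`: 55.7%

In a functional assay on HeLa cells (Homo sapiens) for cytotoxicity, read by MTT assay, with a stated time of 72 h, tested at 10 uM (a higher number here means more inhibition of growth at the concentration tested, a lower number less inhibition of growth), compound 1 gives 72.7% and compound 2 gives 55.7%. Compound 2 thus stands lowest of the two numbers, a number beyond the scatter below compound 1; the two compounds differ in more than one place, so their gap is only what the two values show.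

Compound 3, `N/C(=N\NC(=S)N1CCCC1)c1ccccn1`, has not yet been measured in this assay. It differs from compound 2 by pyrrolidin-1-yl in place of piperidin-1-yl on a thiocarbonyl carbon. Without any measured pair that isolates this change, the expected size of the step can only be bounded loosely. Compound 1, which also carries pyrrolidin-1-yl on the thiocarbonyl carbon, gives 72.7%, and that is the nearest guide. A modest rise from compound 2 is expected, likely not much beyond the scatter, and the step of a number 8.3 percentage points higher from compound 2 to compound 3 (within the scatter) is the estimate. Compound 3 is therefore expected to show 64% in this assay, within a range of 48% to 80%.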

Compound 3, percent growth inhibition at one concentration: 63.5%
The estimate for compound 3 lay 0.5 percentage points above the measured number, within the range that was stated.
By their numbers in this assay, from the lowest: compounds 2, 3 and 1 (each within the scatter of the next, the first and the last beyond it).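

Among these compounds, with compound 3, the exchange of piperidin-1-yl for pyrrolidin-1-yl on a thiocarbonyl carbon can be read on its own for the first time: in this assay it comes to a number 7.8 percentage points higher from compound 2 to compound 3 (within the scatter) and so does not separate the two rings. The same compound isolates the substituent on the aromatic carbon, where the exchange of fluoro for hydrogen gives a number 9.2 percentage points lower from compound 1 to compound 3 (within the scatter) and likewise does not separate the two groups. Nothing measured here offers an explanation for either step.

Each reading rests on a single pair of compounds, so the compounds shown leave open whether azetidin-1-yl, morpholin-4-yl or an open-chain diethylamino group on the thiocarbonyl carbon would give a step beyond the scatter. They also leave open whether chloro, methoxy or a nitrile on that aromatic carbon would stay within the scatter of hydrogen and fluoro, and whether either exchange would give a step of similar size on a different partner group.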